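Cytotoxicity notes: chloro to sulfanyl on the shared core

This account rests on a few compounds, and the source may have more. Where it says the series, first, only, none or still open, it means among the compounds named here.

compound 1 `Nc1nc(Cl)c2nnn(C3CC(O)C(CO)C3)c2n1`: 10 ug/mL
compound 2 `Nc1nc(N)c2nnn(C3CC(O)C(CO)C3)c2n1`: > 100 ug/mL (a limit of the assay, not a number)
compound 3 `Nc1nc(Cl)c2ncn(C3CC(O)C(CO)C3)c2n1`: 62 ug/mL

In an ADME assay on KB cells (Homo sapiens) for cytotoxicity (on this read-out higher numbers stand for an effect only at larger amounts of compound and lower numbers for an effect already at smaller amounts), compound 1 gives 10 ug/mL and compound 3 gives 62 ug/mL, the highest of the two numbers shown. For compound 2 the assay reports only a limit, > 100 ug/mL (the limit of > 100 ug/mL in this assay, at which 1 of the 3 values shown sits). For the measured compounds named here, the single measured step, an at least 10-fold higher number from compound 1 to compound 2 (1.00 log units; beyond the scatter), alters the same aromatic carbon of the shared core that the step at hand alters. Compound 4 `Nc1nc(S)c2ncn(C3CC(O)C(CO)C3)c2n1` differs from compound 3 by sulfanyl in place of chloro on an aromatic carbon. The group that enters here is not the same one, so that earlier step serves only as a rough guide; a rise in number of smaller size is expected, a 1.8-fold higher number from compound 3 to compound 4 (0.25 log units; within the scatter). Compound 4 is therefore expected to give about 110 ug/mL, in the range 45 ug/mL to 300 ug/mL, with a fair chance that this assay reports only a limit.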

Compound 4, concentration for half-maximal effect: > 100 ug/mL
Compound 4 ended at the assay's limit; the forecaster's own chance of this, stated with the estimate: 45%; the middle value is on the limit's open side.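

In this assay, sulfanyl in place of chloro on this aromatic carbon gives an at least 1.6-fold higher number from compound 3 to compound 4 (0.20 log units; that floor lies within the scatter); that figure is only a floor, so the true size of the change cannot be read and may or may not exceed the scatter. Chloro is now replaced at this carbon on two cores, by amino in compound 2 and by sulfanyl in compound 4, and both replacements end at a limit of the assay rather than a number: the limit of > 100 ug/mL in this assay, at which 2 of the 4 values shown sit.

From the compounds shown here alone, how a methoxy group or a methylsulfanyl chain on this aromatic carbon would read stays open, as does whether either would give a number short of that limit.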